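Shortening the hydroxycarbamoyl chain of compound 2

The source may hold more compounds than are shown below. What is called first, only, known or untested is meant among the compounds shown, and "the series" means these compounds.

Among the compounds with values here, in a functional assay on HCT-116 cells (Homo sapiens) for inhibition, read by MTT assay, with a stated time of 72 h (on this read-out lower numbers stand for stronger inhibition and higher numbers for weaker inhibition), compound 2 `Nc1nc2cc(-c3nn(CCCCCCCCC(=O)NO)c4ncnc(N)c34)ccc2o1` gives 2980 nM, the only true number so far. Compound 1 `Nc1nc2cc(-c3nn(CCC(=O)NO)c4ncnc(N)c34)ccc2o1` gives > 100000 nM, which is a limit of the assay.

Compound 3 `Nc1nc2cc(-c3nn(CCCCCCC(=O)NO)c4ncnc(N)c34)ccc2o1` shortens the chain of compound 2: hydroxycarbamoyl in place of 2-(hydroxycarbamoyl)ethyl on a saturated chain carbon, six bonds along the chain from an aromatic nitrogen. In words, hydroxycarbamoyl stands in place of 2-(hydroxycarbamoyl)ethyl on a saturated chain carbon, six bonds along the chain from an aromatic nitrogen. The chain of compound 3 thus remains longer than that of compound 1.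

Within the data shown here, one measured step bears on this change: an at least 33-fold lower number from compound 1 to compound 2 (1.52 log units; beyond the scatter). This large step, beyond the scatter, came with lengthening the chain, so shortening it should move the number the other way. Compound 3 gives up only part of that added length, and two compounds cannot show how the number changes along the chain. A moderate rise in this assay is therefore expected, meaning weaker inhibition, though it may stay close to the scatter.

The expected change is a 1.7-fold higher number from compound 2 to compound 3 (0.22 log units; within the scatter). For compound 3 the estimate is 5000 nM, with an expected range of 1000 nM to 25000 nM.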

Compound 3, half-maximal inhibitory concentration: 5390 nM
Estimate against measurement, compound 3: 1.1-fold (0.03 log units) below; low and high end bracket the measured number.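

In this assay, putting hydroxycarbamoyl in place of 2-(hydroxycarbamoyl)ethyl at the end of the chain gives a 1.8-fold higher number from compound 2 to compound 3 (0.26 log units; within the scatter), so this much of the chain can go without a change that stands out from the usual scatter. The other comparison, an at least 18-fold lower number from compound 1 to compound 3 (1.26 log units; beyond the scatter), shows that the large difference seen earlier is still present at this shorter length, so it is not tied to the full chain of compound 2 and must arise somewhere in the stretch between the chain of compound 1 and the chain of compound 3. Compound 1 gives > 100000 nM, which is a limit and not a number, so any step from it is only a bound: the limit of > 100000 nM in this assay, at which 1 of the 3 values shown sits.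

Three chain lengths cannot show whether the number climbs gradually or abruptly on the way to that limit, and a chain of intermediate length between those of compound 1 and compound 3 would locate the change. As far as these compounds go, it also stays open how much depends on the end group itself, which a carboxylic acid in place of hydroxycarbamoyl on the chain of compound 3 would test.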